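The source may report more compounds than this note shows. Statements on the series, on what has been measured and on what is new or still open speak of the compounds shown alone.

Of the compounds shown here, three sharing one core have been measured in an assay on isolated protein (strain Sprague-Dawley) for inhibition of Amine oxidase [flavin-containing] B (Rattus norvegicus), read by spectrophotometry, with a stated time of 5 min; on this read-out higher numbers stand for weaker inhibition and lower numbers for stronger inhibition. Compound 1 `COCOc1cc(=O)oc2cc(OCc3cccc(Cl)c3)ccc12` gives 100 nM. Compound 2 `CC(=O)COc1cc(=O)oc2cc(OCc3cccc(Cl)c3)ccc12` gives 26.9 nM. Compound 3 `CCOC(=O)COc1cc(=O)oc2cc(OCc3cccc(Cl)c3)ccc12` gives 1820 nM, the highest of the three numbers, so it stands as the weakest inhibitor here, with the step of an 18-fold higher number from compound 1 to compound 3 (1.26 log units; beyond the scatter) and the step of a 68-fold higher number from compound 2 to compound 3 (1.83 log units; beyond the scatter) both well beyond the scatter.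

Compound 4 `O=C(COc1cc(=O)oc2cc(OCc3cccc(Cl)c3)ccc12)N1CCCCC1` has not been measured. It differs from compound 3 by piperidin-1-yl in place of ethoxy on a carbonyl carbon. The step that bears most directly on this change is a 68-fold higher number from compound 2 to compound 3 (1.83 log units; beyond the scatter). It also alters the group on the same carbonyl carbon, and there a change at that position moved the number a great deal. That step, however, went from a methyl group to an ethoxy group, not to a piperidin-1-yl group, so its direction cannot simply be carried over. The other steps, a 3.7-fold lower number from compound 1 to compound 2 (0.57 log units; beyond the scatter) and an 18-fold higher number from compound 1 to compound 3 (1.26 log units; beyond the scatter), touch the chain at a different point and help less.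

Given this, the expected step of a 2.6-fold lower number from compound 3 to compound 4 (0.41 log units; beyond the scatter) is modest, with wide uncertainty. Compound 4 is therefore estimated at 700 nM in this assay, within a range from 120 nM to 4000 nM.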

Compound 4, half-maximal inhibitory concentration: 38900 nM
The estimate for compound 4 lay 56-fold (1.74 log units) below the measured number; measured number above the stated range.
By their numbers in this assay, from the lowest: compound 2; then compound 1; then compound 3; then compound 4.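

In this assay, among the compounds shown here, the group on this carbonyl carbon can push the number much further up than the earlier compounds showed: ethoxy no longer marks the weak end, since a 21-fold higher number from compound 3 to compound 4 (1.33 log units; beyond the scatter) makes compound 4 the weakest inhibitor of the four. Exchanging the methyl group for piperidin-1-yl at this same carbon gives a 1400-fold higher number from compound 2 to compound 4 (3.16 log units; beyond the scatter), the widest gap in the set. The whole side chain matters as well, with a 390-fold higher number from compound 1 to compound 4 (2.59 log units; beyond the scatter), so this part of the molecule tolerates some groups far better than others. No measurement shown here explains the rise. Going by these compounds, it remains open whether the nitrogen on the carbonyl carbon or the six-membered ring matters more, and a dimethylamino group at this carbon would help separate the two.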